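A few compounds are considered here, and "the series" means these few. Any claim that something is new, unique, unknown or untested is made for them only; others in the source may bear on it.

Compound 1 `CCCCSc1nc(C(C)c2c(F)cccc2Cl)c(C)c(=O)[nH]1`: > 1500 nM
Compound 2 `CCC(C)Sc1nc(C(CC)c2c(F)cccc2Cl)c(C)c(=O)[nH]1`: > 3000 nM

Both compounds were tested in an ADME assay on MT4 cells (Homo sapiens) for activation, read by MTT assay; on this read-out higher numbers stand for lower toxicity in this test and lower numbers for higher toxicity in this test. Compound 1 gives > 1500 nM, which is a limit of the assay and not a number. Compound 2 gives > 3000 nM, which is also a limit, so its standing rests on no exact number.

Compound 3 `CCCCSc1nc(C(CC)c2c(F)cccc2Cl)c(C)c(=O)[nH]1` has butyl in place of sec-butyl on a sulfur, and otherwise matches compound 2: butyl in place of sec-butyl on a sulfur.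

Among the measured compounds shown here, no measured pair isolates this change. Compound 1 also carries butyl on the sulfur, and its limit of > 1500 nM gives the expectation its only support. In this assay, a step no larger than the scatter is expected, with the estimate being a number no higher from compound 2 to compound 3 (the limit leaves the size open). For compound 3, the estimated value is 3000 nM. The expected range for compound 3 runs from 1500 nM to 20000 nM.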

Compound 3, half-maximal cytotoxic concentration: > 3000 nM
Compound 3: no number, only a limit (the forecaster's own chance of this, stated with the estimate: 75%); the middle value lies on the limit itself.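

In this assay compound 3 gives > 3000 nM, which is a limit and not a number. Among the compounds shown here, no step from compound 1 or compound 2 to compound 3 can be read, as all three values are limits. The compounds shown leave open whether butyl and sec-butyl on the sulfur differ in half-maximal cytotoxic concentration at all.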